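Extending an aryl group and its expected cost to solubility

The source may report more compounds than this note shows. Statements on the series, on what has been measured and on what is new or still open speak of the compounds shown alone.

Compound 1 `O=[N+]([O-])c1cn2c(n1)OC[C@@H](OC/C=C/c1ccc(OC(F)(F)F)cc1)C2` and compound 3 `O=[N+]([O-])c1cn2c(n1)OC[C@@H](OCCCc1ccc(OC(F)(F)F)cc1)C2` are built on closely related cores, but how the two cores differ is not broken down here. In a physicochemical assay for solubility, read by HPLC, at pH 7 (on this read-out higher numbers stand for higher solubility and lower numbers for lower solubility), compound 1 gives 1.5 ug/mL, while compound 3 gives 11 ug/mL, the highest number among the three measured compounds. Compound 2 `O=[N+]([O-])c1cn2c(n1)OC[C@@H](OC/C=C/c1ccc(-c3ccc(OC(F)(F)F)cc3)cc1)C2` differs from compound 1 by 4-(trifluoromethoxy)phenyl in place of trifluoromethoxy on an aromatic carbon. In this assay compound 2 gives 0.5 ug/mL; the step is a 3.0-fold lower number from compound 1 to compound 2 (0.48 log units; beyond the scatter). Compound 4 `O=[N+]([O-])c1cn2c(n1)OC[C@@H](OCCCc1ccc(-c3ccc(OC(F)(F)F)cc3)cc1)C2` has not been measured yet. It differs from compound 3 by 4-(trifluoromethoxy)phenyl in place of trifluoromethoxy on an aromatic carbon, the same change now made on the core of compound 3; among the compounds shown this change occurs twice. Among the measured compounds shown here, only one measured example of it exists, so the expectation for compound 4 rests on that single step. The estimated step is a 3.0-fold lower number from compound 3 to compound 4 (0.47 log units; beyond the scatter), close in size to the earlier one. Compound 4 is therefore expected to give about 3.7 ug/mL in this assay, most likely between 1.5 ug/mL and 8 ug/mL.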

Compound 4, solubility: 1.7 ug/mL
Beside the measured number, compound 4's estimate is 2.2-fold (0.34 log units) above it; the measured number falls inside the stated range.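

In this assay, putting 4-(trifluoromethoxy)phenyl in place of trifluoromethoxy on an aromatic carbon gives a lower number on both cores, first (a 3.0-fold lower number from compound 1 to compound 2 (0.48 log units; beyond the scatter)) and now (a 6.5-fold lower number from compound 3 to compound 4 (0.81 log units; beyond the scatter)), and both steps lie beyond the usual scatter. This shows that the direction of the change carried over from one closely related core to the other, but two pairs make no general rule and cannot show how large the step would be on any other core, or whether its size depends on the core at all. Nothing measured here bears on why the number falls in either pair.

The compounds shown leave open how the same change would read out on a core carrying a longer chain in the linker to the aromatic ring. They also leave open what an amine or a carboxylic acid would give in place of the trifluoromethoxy group.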